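Biphenyl ether imidazole acids: methoxy to dimethyl swap

A few compounds are considered here, and "the series" means these few. Any claim that something is new, unique, unknown or untested is made for them only; others in the source may bear on it.

Measured compounds:
compound 1 `COc1ccccc1-c1cccc(COc2ccc([C@H](CC(=O)O)c3nccn3C)cc2)c1` — "not determined" (no result reported)
compound 2 `Cn1ccnc1[C@@H](CC(=O)O)c1ccc(OCc2cccc(-c3ccc(Cl)cc3Cl)c2)cc1` — 30000 nM
compound 3 `Cc1cc(Cl)ccc1-c1cc(COc2ccc([C@H](CC(=O)O)c3nccn3C)cc2)ccc1C` — 9800 nM

Compound 1 carries a 2-methoxyphenyl on the shared core. In an assay on CHO cells for agonist activity at Free fatty acid receptor 1 (Homo sapiens), read by luminescence, with a stated time of 20 s, in the presence of a further agent that is not named here (a lower number here means that less compound is needed, a higher number that more compound is needed for the effect), compound 1 is recorded as "not determined" (no result reported), so it stands nowhere on the numbers; its position can only be framed by the other two. In this assay compound 2 gives 30000 nM and compound 3 gives 9800 nM; both sit at the weak end, and the gap between them is beyond the usual scatter.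

Compound 4 `Cc1cccc(C)c1-c1cccc(COc2ccc([C@H](CC(=O)O)c3nccn3C)cc2)c1` differs from compound 1 as follows: 2,6-dimethylphenyl in place of 2-methoxyphenyl on an aromatic carbon. For the measured compounds named here, with no result for compound 1, no step can be computed, and no expectation about direction or size of the step can be drawn from a parent value; the only anchor is that the two measured analogues with substituted terminal aryls lie in the weak range.

Compound 4 is expected to fall in that same weak range, estimated at 15000 nM with a range from 4000 nM to 50000 nM.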

Compound 4, half-maximal effective concentration: 29000 nM
For compound 4 the middle estimate is 1.9-fold (0.29 log units) below the measured one, and the stated range covers the measured number.
By their numbers in this assay, from the lowest: compound 3; then compounds 4 and 2 (each within the scatter of the next).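

In this assay the exchange of 2,4-dichlorophenyl for 2,6-dimethylphenyl on this aromatic carbon gives a 1.0-fold lower number from compound 2 to compound 4 (0.01 log units; within the scatter) and so leaves the number unchanged within the scatter. At this position, meta to a large group, a terminal aryl with two methyl groups and one with two chlorines therefore cannot be told apart, and both stay at the weak end of the assay. No available evidence bears on the reason for this result.

As far as these compounds go, the step from compound 1 to compound 4 cannot be read, as compound 1 has no number, so the standing of 2-methoxyphenyl relative to 2,6-dimethylphenyl stays unknown. Also open, from the compounds shown here alone, is whether a terminal aryl carrying an amine or a carboxylic acid would move the number out of this weak range.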